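The source may hold more compounds than are shown below. What is called first, only, known or untested is meant among the compounds shown, and "the series" means these compounds.

Compound 1, with the structure `COc1cc2c(Oc3ccc(NC(=O)c4nn(-c5ccccc5C)c(=O)cc4C)cc3F)ccnc2cc1OCCCN1CCC(C)CC1`, gives 1460 nM in a functional assay on A549 cells (Homo sapiens) for inhibition, read by MTT assay, with a stated time of 72 h; a lower number here means a stronger inhibitor, a higher number a weaker inhibitor. Compound 2, `COc1cc2c(Oc3ccc(NC(=O)c4nn(-c5ccccc5C)c(=O)cc4C)cc3F)ccnc2cc1OCCCN1CCN(C)CC1`, gives 2830 nM in this assay. The change between them is 4-methylpiperazin-1-yl in place of 4-methylpiperidin-1-yl on a saturated chain carbon, three bonds along the chain from an oxygen on an aromatic ring, and it gave a 1.9-fold higher number from compound 1 to compound 2 (0.29 log units; within the scatter). Compound 3, `COc1cc2c(Oc3ccc(NC(=O)c4nn(-c5ccccc5OC(F)(F)F)c(=O)cc4C)cc3F)ccnc2cc1OCCCN1CCC(C)CC1`, gives 90 nM in this assay; the difference from compound 1 is trifluoromethoxy in place of methyl on an aromatic carbon, which gave a 16-fold lower number from compound 1 to compound 3 (1.21 log units; beyond the scatter), leaving compound 3 with the lowest number of the three. Compound 4, `COc1cc2c(Oc3ccc(NC(=O)c4nn(-c5ccccc5OC(F)(F)F)c(=O)cc4C)cc3F)ccnc2cc1OCCCN1CCN(C)CC1`, is not yet measured in this assay. It differs from compound 3 by 4-methylpiperazin-1-yl in place of 4-methylpiperidin-1-yl on a saturated chain carbon, three bonds along the chain from an oxygen on an aromatic ring, the same change that separates compound 2 from compound 1. Because that change gave a 1.9-fold higher number from compound 1 to compound 2 (0.29 log units; within the scatter), a step of similar size is expected here, a 1.9-fold higher number from compound 3 to compound 4 (0.28 log units; within the scatter). Compound 4 is therefore estimated at 170 nM in this assay, with a likely range from 70 nM to 420 nM.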

Compound 4, half-maximal inhibitory concentration: 130 nM
For compound 4 the middle estimate is 1.3-fold (0.12 log units) above the measured one, within the range that was stated.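

In this assay, 4-methylpiperazin-1-yl in place of 4-methylpiperidin-1-yl gave a 1.4-fold higher number from compound 3 to compound 4 (0.16 log units; within the scatter), and this step does not differ from its earlier counterpart on the other core: the same change on two cores in this assay, a 1.9-fold higher number (0.29 log units; within the scatter) from compound 1 to compound 2 and a 1.4-fold higher number (0.16 log units; within the scatter) from compound 3 to compound 4, 1.3-fold (0.13 log units) apart, within the scatter of two such steps. Trifluoromethoxy in place of methyl gave a 22-fold lower number from compound 2 to compound 4 (1.34 log units; beyond the scatter), and it also kept its size from one core to the other: the same change on two cores in this assay, a 16-fold lower number (1.21 log units; beyond the scatter) from compound 1 to compound 3 and a 22-fold lower number (1.34 log units; beyond the scatter) from compound 2 to compound 4, 1.3-fold (0.13 log units) apart, within the scatter of two such steps. This shows that each change carried over between the two cores in these four compounds, but it does not show that either would carry over to any other core, and both steps of the amine change lie within the scatter.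

The compounds shown leave open how a morpholine or a longer chain in place of the propyl chain would behave. They also leave open whether a chlorine or a methoxy group in place of trifluoromethoxy would give a step of similar size.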